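A few compounds are considered here, and "the series" means these few. Any claim that something is new, unique, unknown or untested is made for them only; others in the source may bear on it.

In a functional assay on SW480 cells (Homo sapiens) for antiproliferative activity (on this read-out lower numbers stand for stronger inhibition and higher numbers for weaker inhibition), compound 1 `COc1cccc(/C=C/C(=O)c2ccc(OCCn3cc(CN4C(=O)/C=C/C(C)(C)C/C=C(\C)CC/C=C/4C)nn3)cc2O)c1` reads 0.95 ug/mL while compound 2 `COc1ccc(/C=C/C(=O)c2ccc(OCCCN3C(=O)/C=C/C(C)(C)C/C=C(\C)CC/C=C/3C)cc2)cc1` reads 2.92 ug/mL and so holds the higher of the two numbers, a gap beyond the usual scatter of repeat measurements. Compound 3 `COc1ccccc1/C=C/C(=O)c1ccc(OCCCN2C(=O)/C=C/C(C)(C)C/C=C(\C)CC/C=C/2C)cc1` has not been measured yet. It carries the same atoms as compound 2, joined differently: 2-methoxyphenyl in place of 4-methoxyphenyl on a double-bonded chain carbon bound to a double-bonded chain carbon is the whole change, with 2-methoxyphenyl in place of 4-methoxyphenyl on a double-bonded chain carbon bound to a double-bonded chain carbon. Going by the values given here, compound 1 differs from compound 2 in more than one place, so no measured pair shows what this swap does. With so little to go on, the expectation in this assay is no step beyond the scatter in either direction, taking compound 2 at 2.92 ug/mL as the starting point. The expected change, a 1.1-fold higher number from compound 2 to compound 3 (0.04 log units; within the scatter), is therefore small. For compound 3 the estimated value is 3.2 ug/mL with an expected range from 1.4 ug/mL to 7.5 ug/mL for a single measurement.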

Compound 3, half-maximal inhibitory concentration: 1.33 ug/mL
Compound 3: middle estimate off by 2.4-fold (0.38 log units), on the high side; measured number outside the range, below it.
By their numbers in this assay, from the lowest: compounds 1 and 3 (each within the scatter of the next); then compound 2.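

In this assay, placing 2-methoxyphenyl in place of 4-methoxyphenyl on a double-bonded chain carbon bound to a double-bonded chain carbon gives a 2.2-fold lower number from compound 2 to compound 3 (0.34 log units; beyond the scatter), so this position responds to the swap, though the step is modest. The two groups have the same atoms and the same counts of heavy atoms, hydrogen-bond donors and hydrogen-bond acceptors, so these counts do not separate them. Nothing available here accounts for why this rearrangement lowers the number.

Compound 1 differs from compound 2 and compound 3 in more than one place, so it cannot show whether the same swap would have a similar effect on another part of the series. On these data alone, it also remains open whether the lower number depends on the methoxy group itself, a question that a 2-ethoxyphenyl or 2-aminophenyl group in the same place could help to answer.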